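Ethoxy for cyclopentyl on the ring-nitrogen carbonyl

This account rests on a few compounds, and the source may have more. Where it says the series, first, only, none or still open, it means among the compounds named here.

Compound 1 `CCNC(=O)Nc1sc2ccccc2c1C(=O)N1CCN(C2CCN(C(=O)CC(C)C)CC2)CC1` belongs to the series, but in a functional assay on HepG2 cells (Homo sapiens) for inhibition, read by scintillation counting, with a stated time of 2 h (on this read-out lower numbers stand for stronger inhibition and higher numbers for weaker inhibition), compound 1 has "not determined" (no result reported). Among the measured compounds shown here, compound 2 `CCNC(=O)Nc1sc2ccccc2c1C(=O)N1CCN(C2CCN(C(=O)C3CCCC3)CC2)CC1` is therefore the only member with a number: in this assay compound 2 gives 309 nM. For the measured compounds named here, no step between two measured compounds is available, so nothing about the sensitivity of this position can be read from data in hand.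

Compound 3 `CCNC(=O)Nc1sc2ccccc2c1C(=O)N1CCN(C2CCN(C(=O)OCC)CC2)CC1` differs from compound 2 in one place: ethoxy in place of cyclopentyl on a carbonyl carbon. The place is a carbonyl carbon whose other neighbours are an amide-type nitrogen in a ring; cut one bond further out, the same difference reads cyclopentylcarbonyl to ethoxycarbonyl. Lacking a measured step, the step expected in this assay is a 1.6-fold higher number from compound 2 to compound 3 (0.21 log units; within the scatter), a modest weakening that may well sit inside the scatter. Compound 3 is accordingly estimated at 500 nM in this assay, with a range of 150 nM to 1600 nM.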

Compound 3, half-maximal inhibitory concentration: 228 nM
Beside the measured number, compound 3's estimate is 2.2-fold (0.34 log units) above it; the measured number falls inside the stated range.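

In this assay, among the compounds shown here, the first readable step at this position is a 1.4-fold lower number from compound 2 to compound 3 (0.13 log units; within the scatter), so ethoxy and cyclopentyl on the carbonyl carbon cannot be told apart in this read-out. The carbonyl carbon can therefore carry ethoxy, with its oxygen and no ring, in place of the five-membered carbon ring without the values of the pair separating beyond the scatter. No measurement in hand offers an explanation for this result.

Steps involving compound 1 cannot be read, so this single pair is the only guide to how the position responds to change. As far as these compounds go, whether an amine, a carboxylic acid or a longer chain on the same carbonyl carbon would also leave the number within the scatter of compound 2 and compound 3 remains open.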